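Methoxy in place of hydrogen on compound 2

This account rests on a few compounds, and the source may have more. Where it says the series, first, only, none or still open, it means among the compounds named here.

In a functional assay on Hep 3B2 cells (Homo sapiens) for cytotoxicity, read by MTT assay, with a stated time of 48 h (a higher number here means a weaker inhibitor, a lower number a stronger inhibitor), compound 1 `COc1cc(C2Oc3c(OC)cc(/C=C/C=O)cc3C2CO)ccc1O` reads 29300 nM and compound 2 `COc1cc([C@H]2Oc3c(OC)cc(/C=C/C=O)cc3[C@@H]2CO)ccc1O` reads 22400 nM with the two inside the scatter of each other. For the measured compounds named here, the one measured step (a 1.3-fold lower number from compound 1 to compound 2 (0.12 log units; within the scatter)) concerns drawn configuration only and sets no size for a new group. Compound 3 `COc1cc([C@H]2Oc3c(OC)cc(/C=C/C=O)cc3[C@@H]2CO)cc(OC)c1O` differs from compound 2 by methoxy in place of hydrogen on an aromatic carbon, ortho to a hydroxy group (methoxy in place of hydrogen on an aromatic carbon). The expected move in this assay is a 1.0-fold lower number from compound 2 to compound 3 (0.01 log units; within the scatter) and thus none beyond the scatter. Compound 3 is estimated at 22000 nM (range 9000 nM to 55000 nM).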

Compound 3, half-maximal inhibitory concentration: 72800 nM
Compound 3: the middle estimate sits 3.3-fold (0.52 log units) below what was measured; the whole stated range lies below it.
By their numbers in this assay, from the lowest: compounds 2 and 1 (each within the scatter of the next); then compound 3.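

In this assay, the aromatic carbon ortho to a hydroxy group does not tolerate every change silently: methoxy in place of hydrogen gives a 3.3-fold higher number from compound 2 to compound 3 (0.51 log units; beyond the scatter), so the series weakens modestly with this group. For the compounds shown here, this is the first step beyond the scatter. Nothing available bears on the cause of this step.

As far as these compounds go, whether any group at this carbon weakens the series, or methoxy in particular, remains open. Fluorine, ethoxy or an amine at this place would begin to separate those two readings.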